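Cyclobutyl amine variation in the aminonicotinonitrile series

The source may report more compounds than this note shows. Statements on the series, on what has been measured and on what is new or still open speak of the compounds shown alone.

Measured compounds in an assay on isolated protein for inhibition of protein kinase C theta type (Homo sapiens), read by TR-FRET, with a stated time of 2 h; on this read-out higher numbers stand for weaker inhibition and lower numbers for stronger inhibition:
compound 1 `N#Cc1cnc(NCc2cnccc2C(F)(F)F)cc1NC[C@H]1C[C@H](O)C1`: 700 nM
compound 2 `N#Cc1cnc(NCc2ccccc2C(F)(F)F)cc1N[C@H]1C[C@H](C(N)=O)C1`: 5000 nM
compound 3 `N#Cc1cnc(NCc2cncnc2-c2ccccc2)cc1N[C@H]1CC[C@@H](O)CC1`: 90 nM

Compound 1 holds the second highest of the three numbers; compound 2 lies at a higher number and compound 3 at a lower one, both gaps beyond the scatter. Compound 4 `CC1(C)[C@H](Nc2cc(NCc3cnccc3C(F)(F)F)ncc2C#N)C[C@H]1C(N)=O` is not yet measured. It differs from compound 1 by 3-carbamoyl-2,2-dimethylcyclobutyl in place of (3-hydroxycyclobutyl)methyl on a nitrogen on an aromatic ring. Within the data shown here, no measured pair carries this change. Compound 2, which also bears a carbamoyl-substituted cyclobutyl directly on the ring nitrogen, shows a higher number than compound 1, so a step toward a higher number in this assay is expected, likely beyond the scatter, as a 2.1-fold higher number from compound 1 to compound 4 (0.33 log units; beyond the scatter). Compound 4 is estimated at 1500 nM, with a range from 400 nM to 6000 nM.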

Compound 4, half-maximal inhibitory concentration: 140 nM
For compound 4 the middle estimate is 11-fold (1.03 log units) above the measured one; the whole stated range lies above it.
By their numbers in this assay, from the lowest: compounds 3 and 4 (each within the scatter of the next); then compound 1; then compound 2.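

In this assay, among these compounds, the step at this position gives a 5.0-fold lower number from compound 1 to compound 4 (0.70 log units; beyond the scatter), the first reading of a change made at this position alone. On a nitrogen on an aromatic ring, the larger 3-carbamoyl-2,2-dimethylcyclobutyl is therefore accepted in place of (3-hydroxycyclobutyl)methyl on the core of compound 1. Nothing measured here accounts for this step.

This single step swaps the ring's attachment, its substituent and its methyl groups together, so their separate shares remain unresolved. Also open, going by these compounds, is how a carboxylic acid or a primary amine in place of the carbamoyl group would read on this cyclobutyl.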